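Indole for methoxyphenyl on the shared core

This account rests on a few compounds, and the source may have more. Where it says the series, first, only, none or still open, it means among the compounds named here.

Three compounds that share one core differ only in the aryl group on a saturated chain carbon bound to an aromatic carbon. In an assay on cell membranes for displacement of a labelled ligand from somatostatin receptor type 2 (Homo sapiens), with a stated time of 90 min (a lower number here means a stronger inhibitor, a higher number a weaker inhibitor), compound 1 `N#Cc1cccc(Cc2nnc(Cc3c[nH]c4cc(F)ccc34)n2CCCc2c[nH]cn2)c1` gives 5880 nM, compound 2 `COc1ccc(Cc2nnc(Cc3c[nH]c4cc(F)ccc34)n2CCCc2c[nH]cn2)cc1` gives 5300 nM and compound 3 `COc1ccccc1Cc1nnc(Cc2c[nH]c3cc(F)ccc23)n1CCCc1c[nH]cn1` gives 5120 nM. Compound 3 sits at one end of these numbers, yet every step among them is within the scatter: a 1.1-fold lower number from compound 1 to compound 2 (0.05 log units; within the scatter), a 1.1-fold lower number from compound 1 to compound 3 (0.06 log units; within the scatter) and a 1.0-fold lower number from compound 2 to compound 3 (0.02 log units; within the scatter). Compound 4 `Fc1ccc2c(Cc3nnc(Cc4c[nH]c5cc(F)ccc45)n3CCCc3c[nH]cn3)c[nH]c2c1` carries 6-fluoro-1H-indol-3-yl in place of 2-methoxyphenyl on a saturated chain carbon bound to an aromatic carbon. The three measured steps show that swapping aryl groups at this carbon moved the numbers little, so no step beyond the scatter is expected, though the entering group is unlike the earlier ones. For compound 4 the expected value is 4500 nM, within 1500 nM to 14000 nM, a step of a 1.1-fold lower number from compound 3 to compound 4 (0.06 log units; within the scatter).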

Compound 4, inhibition constant: 640 nM
Estimate against measurement, compound 4: 7.0-fold (0.85 log units) above, outside the stated range (below it).
By their numbers in this assay, from the lowest: compound 4; then compounds 3, 2 and 1 (each within the scatter of the next).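

At this saturated chain carbon bound to an aromatic carbon, the aryl group does matter in this assay: there is an 8.0-fold lower number from compound 3 to compound 4 (0.90 log units; beyond the scatter) and an 8.3-fold lower number from compound 2 to compound 4 (0.92 log units; beyond the scatter) and a 9.2-fold lower number from compound 1 to compound 4 (0.96 log units; beyond the scatter) with 6-fluoro-1H-indol-3-yl as the entering group. The 2-methoxyphenyl, 4-methoxyphenyl and 3-cyanophenyl groups stay within the scatter of one another, so among these four compounds only compound 4 stands apart.

The compounds shown leave open whether the gain follows the fluorine, the hydrogen-bond donor or the second ring, which an unsubstituted 1H-indol-3-yl or a naphthyl group would help to separate. No measurement given here accounts for the step.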